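A few compounds are considered here, and "the series" means these few. Any claim that something is new, unique, unknown or untested is made for them only; others in the source may bear on it.

Compound 1 `O=C1C=CN(C(=O)Nc2cc(OCCO)c(Cl)cc2Br)[C@H](c2ccc(F)cc2)C1`: 40 nM
Compound 2 `COc1cc(NC(=O)N2C=CC(=O)C[C@H]2c2ccc(F)cc2)c(Br)cc1Cl`: 37 nM

In an assay on 1321-N1 cells for antagonist activity at P2X purinoceptor 7 (Homo sapiens), read by FLIPR, with stated times of 20 min, 1 s and 60 s, in the presence of a further agent that is not named here (a lower number here means a stronger inhibitor, a higher number a weaker inhibitor), compound 1 holds the highest of the two numbers, and compound 2 sits close to it. Within the data shown here, the one measured step, a 1.1-fold lower number from compound 1 to compound 2 (0.03 log units; within the scatter), concerns a saturated chain carbon bound to an oxygen on the aromatic ring and stays within the scatter, so the two compounds cannot be told apart on these numbers.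

Compound 3 `Cc1cc(Cl)c(OCCO)cc1NC(=O)N1C=CC(=O)C[C@H]1c1ccc(F)cc1` is obtained from compound 1 by methyl in place of bromo on an aromatic carbon. Among the measured compounds shown here, no measured step touches this aromatic carbon; the only step available, from compound 1 to compound 2, concerns another position and shows no shift beyond the scatter. There is therefore no basis in the data for a large shift in this assay, and the expectation is a small step of uncertain direction. Compound 3 is estimated at 70 nM, with a range of 25 nM to 200 nM, corresponding to an expected step of a 1.8-fold higher number from compound 1 to compound 3 (0.24 log units; within the scatter).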

Compound 3, half-maximal inhibitory concentration: 9 nM
Compound 3: middle estimate off by 7.8-fold (0.89 log units), on the high side, and the stated range ends above it.
By their numbers in this assay, from the lowest: compound 3; then compounds 2 and 1 (each within the scatter of the next).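

In this assay, the aromatic carbon that carried bromo is the first place shown where a change moves the number beyond the scatter: methyl in place of bromo gives a 4.4-fold lower number from compound 1 to compound 3 (0.65 log units; beyond the scatter). Bromo is therefore not required at this carbon for activity in this series, and the two groups, which count the same single heavy atom and add no hydrogen-bond donor or acceptor, still differ in this assay. No available evidence accounts for the step.

The compounds shown leave open whether ethyl, trifluoromethyl or an amine on this aromatic carbon would lower the number further or raise it. They also leave open whether methyl would give a similar step with methoxy in place of the 2-hydroxyethoxy group.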